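The compounds below may be only part of what the source reports. "The series", "measured", "known", "first", "only" and "open" are said of these compounds alone.

Measured so far in a functional assay on A549 cells (Homo sapiens) for cytotoxicity, read by MTT assay, with a stated time of 72 h; a lower number here means a stronger inhibitor, a higher number a weaker inhibitor:
compound 1 `CN(C)Cc1ccc2nc(NC(=O)N/N=C/c3cn(Cc4ccccc4)c4ccccc34)sc2c1` — 2900 nM
compound 2 `CCN(CC)Cc1ccc2nc(NC(=O)N/N=C/c3cn(Cc4ccccc4)c4ccccc34)sc2c1` — 3330 nM
compound 3 `CC1CCN(Cc2ccc3nc(NC(=O)N/N=C/c4cn(Cc5ccccc5)c5ccccc45)sc3c2)CC1` — 2340 nM

Compound 1 sits among the three without separation that counts: a 1.1-fold higher number from compound 1 to compound 2 (0.06 log units; within the scatter) and a 1.2-fold lower number from compound 1 to compound 3 (0.09 log units; within the scatter), and likewise a 1.4-fold lower number from compound 2 to compound 3 (0.15 log units; within the scatter). All three measured steps vary only the amine on the saturated chain carbon bound to an aromatic carbon; none of them touches the benzyl group.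

Compound 4 `CN(C)Cc1ccc2nc(NC(=O)N/N=C/c3cn(Cc4cccc(Cl)c4)c4ccccc34)sc2c1` differs from compound 1 by chloro in place of hydrogen on an aromatic carbon. Among the measured compounds shown here, no measured step bears on this change, so the series gives no basis for expecting a shift beyond the scatter in this assay. The expected step is a 1.1-fold lower number from compound 1 to compound 4 (0.05 log units; within the scatter). Compound 4 is expected to give 2600 nM, with a range of 1200 nM to 5800 nM.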

Compound 4, half-maximal inhibitory concentration: 1240 nM
Compound 4: the middle estimate sits 2.1-fold (0.32 log units) above what was measured; low and high end bracket the measured number.
By their numbers in this assay, from the lowest: compounds 4, 3, 1 and 2 (each within the scatter of the next, the first and the last beyond it).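

Unlike the amine swaps, which all stayed within the scatter, the benzyl group responds: 3-chlorobenzyl in place of benzyl gives a 2.3-fold lower number from compound 1 to compound 4 (0.37 log units; beyond the scatter) in this assay, the first single-place change in the series to clear the scatter, though modestly. No available evidence accounts for this shift. The finding rests on one pair, carrying dimethylamino as the amine. Open, going by these compounds, are whether fluoro, methoxy or a nitrile on this ring would move the number likewise, and whether chloro carries over alongside diethylamino or 4-methylpiperidin-1-yl.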